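Sulfanyl side-chain variation on the shared core

The source may report more compounds than this note shows. Statements on the series, on what has been measured and on what is new or still open speak of the compounds shown alone.

Measured in a functional assay on MGC-803 cells (Homo sapiens) for inhibition, read by MTT assay, with a stated time of 72 h; on this read-out lower numbers stand for stronger inhibition and higher numbers for weaker inhibition:
- compound 1 `Cc1ccc(CSc2nc3nc(C)cc(Nc4cc(-c5ccccc5)[nH]n4)n3n2)cc1` gives 6960 nM
- compound 2 `Cc1cc(Nc2cc(-c3ccccc3)[nH]n2)n2nc(SCCc3ccccc3)nc2n1` gives 5620 nM
- compound 3 `Cc1cc(Nc2ccn(Cc3ccccc3)n2)n2nc(SCc3ccc(Br)cc3)nc2n1` gives 4720 nM

Compound 2 stands second highest of the three numbers in this assay. Its nearest neighbour is compound 3 and its furthest is compound 1, and both of those gaps lie within the scatter, so the three measured compounds cannot be told apart on this read-out.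

Compound 4 `COc1ccc(CSc2nc3nc(C)cc(Nc4cc(-c5ccccc5)[nH]n4)n3n2)cc1` is the unmeasured member. It differs from compound 2 in one place: 4-methoxyphenyl in place of benzyl on a saturated chain carbon bound to a sulfur.

Within the data shown here, the only measured step that bears on this is the one at the same place, the group on the saturated chain carbon bound to a sulfur: a 1.2-fold lower number from compound 1 to compound 2 (0.09 log units; within the scatter). That change made no difference beyond the scatter. Among the measured compounds shown here, no measured compound carries a 4-methoxyphenyl group, so nothing speaks to the entering group itself. The expectation for compound 4 is therefore a step of no more than the scatter in this assay, in no particular direction: a 1.0-fold lower number from compound 2 to compound 4 (0.01 log units; within the scatter).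

Compound 4 is estimated at 5500 nM, with a range from 2500 nM to 12000 nM.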

Compound 4, half-maximal inhibitory concentration: 3170 nM
For compound 4 the middle estimate is 1.7-fold (0.24 log units) above the measured one, and the stated range covers the measured number.
By their numbers in this assay, from the lowest: compounds 4, 3, 2 and 1 (each within the scatter of the next, the first and the last beyond it).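

In this assay, the group on the saturated chain carbon bound to a sulfur now gives its first step beyond the scatter, a modest one (a 2.2-fold lower number from compound 1 to compound 4 (0.34 log units; beyond the scatter)) for methoxy in place of methyl on an aromatic carbon. The step read through the benzyl and 4-methoxyphenyl change stays within the scatter (a 1.8-fold lower number from compound 2 to compound 4 (0.25 log units; within the scatter)), so this position has shown a response in one comparison only, and a small one. No measurement on these compounds accounts for the step.

Going by these compounds, whether this single comparison marks a real trend at the aromatic carbon remains open, as the series holds only methyl and methoxy there in this setting. A hydroxy or dimethylamino group at that place, or a chain longer than phenethyl on the sulfur, would test how far the number can move.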